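This account rests on a few compounds, and the source may have more. Where it says the series, first, only, none or still open, it means among the compounds named here.

In an assay on CHO cells for displacement of a labelled ligand from prostaglandin E2 receptor EP1 subtype (Mus musculus), read by scintillation counting, with a stated time of 20 min (on this read-out higher numbers stand for weaker inhibition and lower numbers for stronger inhibition), compound 2 `O=C(O)c1csc(SCCN2C(=O)CC[C@@H]2/C=C/[C@@H](O)Cc2cccc(-c3ccc(Cl)cc3)c2)n1` gives 6300 nM, the highest of the two numbers at hand. For the measured compounds named here, compound 1 `O=C(O)c1csc(SCCN2C(=O)CC[C@@H]2/C=C/[C@@H](O)Cc2cccc(-c3ccccc3)c2)n1` gives 4200 nM in this assay, and the only measured step, a 1.5-fold higher number from compound 1 to compound 2 (0.18 log units; within the scatter), is within the scatter. Compound 3 `O=C(O)c1csc(SCCN2C(=O)CC[C@@H]2/C=C/[C@@H](O)Cc2cccc(-c3nc4ccccc4o3)c2)n1` differs from compound 2 by 1,3-benzoxazol-2-yl in place of 4-chlorophenyl on an aromatic carbon. No measured step covers a heteroaryl in place of an aryl here, and the one step shown concerns a different change, so it carries little weight for this one; no shift beyond the scatter is expected. Compound 3 is therefore estimated at 5000 nM, within a range of 1500 nM to 16000 nM, which would mean a step of a 1.3-fold lower number from compound 2 to compound 3 (0.10 log units; within the scatter).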

Compound 3, inhibition constant: > 10000 nM
Compound 3 gave a limit, no number (the forecaster's own chance of this, stated with the estimate: 10%); at least 2.0-fold (0.30 log units) between middle value and limit.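

For the compounds shown here, replacing phenyl with 1,3-benzoxazol-2-yl gives the first change on this aromatic carbon that lies beyond the scatter (an at least 2.3-fold higher number from compound 1 to compound 3 (0.37 log units; beyond the scatter)). Against 4-chlorophenyl, the same group gives a step whose floor lies within the scatter (an at least 1.5-fold higher number from compound 2 to compound 3 (0.20 log units; that floor lies within the scatter)), so that step fixes no size. Compound 3 gives a limit and not a number: the limit of > 10000 nM in this assay, at which 1 of the 3 values shown sits.

Going by these compounds, how far the true value of compound 3 lies past that limit stays open. So does whether a pyridinyl ring or a 4-methoxyphenyl group on this aromatic carbon would give a lower number than phenyl.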